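The source may report more compounds than this note shows. Statements on the series, on what has been measured and on what is new or still open speak of the compounds shown alone.

Measured in an ADME assay on L02 cells (Homo sapiens) for antiproliferative activity, read by MTT assay, with a stated time of 48 h; on this read-out higher numbers stand for weaker inhibition and lower numbers for stronger inhibition:
- compound 1 `CCOC(=O)CN(C)C(=O)c1ccc(C(CC)(CC)c2ccc(OCCC(O)(CC)CC)c(C)c2)n1CC`: 1990 nM
- compound 2 `CCn1c(C(=O)NC(C)C(=O)O)ccc1C(CC)(CC)c1ccc(OCCC(O)(CC)CC)c(C)c1`: 4040 nM
- compound 3 `CCn1c(C(=O)NC(CO)CCO)ccc1C(CC)(CC)c1ccc(OCCC(O)(CC)CC)c(C)c1`: 3040 nM

Compound 3, at 3040 nM, lies within the scatter of both other compounds, although those two are separated by a modest step beyond it, a 2.0-fold higher number from compound 1 to compound 2 (0.31 log units; beyond the scatter).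

The next compound is compound 4 `CCn1c(C(=O)NC(C)CO)ccc1C(CC)(CC)c1ccc(OCCC(O)(CC)CC)c(C)c1`, with this difference: hydrogen in place of hydroxymethyl on a saturated chain carbon, two bonds along the chain from an amide-type nitrogen. It places hydrogen in place of hydroxymethyl on a saturated chain carbon, two bonds along the chain from an amide-type nitrogen.

Two measured changes at the same amide substituent stayed within the scatter: a 1.3-fold lower number from compound 2 to compound 3 (0.12 log units; within the scatter) and a 1.5-fold higher number from compound 1 to compound 3 (0.18 log units; within the scatter). No step beyond the scatter is therefore expected in this assay. The expected step is a 1.0-fold lower number from compound 3 to compound 4 (0.01 log units; within the scatter). For compound 4 the estimate is 3000 nM, with an expected range of 1500 nM to 6000 nM.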

Compound 4, half-maximal inhibitory concentration: 4840 nM
Beside the measured number, compound 4's estimate is 1.6-fold (0.21 log units) below it, and the stated range covers the measured number.
By their numbers in this assay, from the lowest: compounds 1, 3, 2 and 4 (each within the scatter of the next, the first and the last beyond it).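

Hydrogen in place of hydroxymethyl on this saturated chain carbon gives a 1.6-fold higher number from compound 3 to compound 4 (0.20 log units; within the scatter) and hydroxymethyl in place of carboxy gives a 1.2-fold higher number from compound 2 to compound 4 (0.08 log units; within the scatter) so neither change at this amide substituent moves the number beyond the scatter. For the compounds shown here, the only new step beyond the scatter is a 2.4-fold higher number from compound 1 to compound 4 (0.39 log units; beyond the scatter) on replacing the ((ethoxycarbonyl)methyl)(methyl)amino group, and it is modest. No measurement at hand gives a reason for these steps.

Still open, on these data alone, is how an amine or a longer chain on this saturated chain carbon would read, and whether any group there moves the number beyond the scatter.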